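The source may report more compounds than this note shows. Statements on the series, on what has been measured and on what is new or still open speak of the compounds shown alone.

Measured compounds:
- compound 1 `CCOC(=O)C1=C(Nc2ccccc2)S/C(=C\c2ccccc2)C1=O`: in a functional assay on A549 cells (Homo sapiens) for inhibition, read by MTT assay, with a stated time of 72 h, tested at 10 uM (a higher number here means more inhibition at the concentration tested (going by the name of the read-out), a lower number less inhibition), compound 1 gives 29.6%
- compound 2 `CCOC(=O)C1=C(Nc2ccccc2)S/C(=C\c2ccc(C(=O)O)cc2)C1=O`: compound 2 gives 11.6%
- compound 3 `CCOC(=O)C1=C(Nc2ccccc2)S/C(=C\c2cccc(C(=O)O)c2)C1=O`: compound 3 reaches only the limit < 10%

Compound 1 stands highest of the two numbers shown; its nearest neighbour is compound 2, reached by a number 18 percentage points lower from compound 1 to compound 2 (beyond the scatter). The value of compound 3 is a limit of this assay and not a number (the limit of < 10% in this assay, at which 1 of the 3 values shown sits). The two steps from compound 1 both put a carboxy group onto the ring at the end of the double-bonded chain: a number 18 percentage points lower from compound 1 to compound 2 (beyond the scatter) and a number at least 19.6 percentage points lower from compound 1 to compound 3 (beyond the scatter). Between the two carboxy isomers, a number at least 1.6 percentage points lower from compound 2 to compound 3 (that floor lies within the scatter).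

Compound 4 `CCOC(=O)C1=C(Nc2ccccc2)S/C(=C\c2ccccc2C(F)(F)F)C1=O` is yet unmeasured. The change from compound 1 is trifluoromethyl in place of hydrogen on an aromatic carbon. Neither measured step bears on it directly: both introduce a carboxy group, a different group, and neither sits ortho to a large group. For the measured compounds named here, they show only that the number in this assay came out lower after each carboxy addition to the ring in question. With no closer guide, a step smaller than those, possibly within the scatter, is expected. For compound 4 the expected value in this assay is 24%, within 10% to 42%, which means an expected step of a number 5.6 percentage points lower from compound 1 to compound 4 (within the scatter).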

Compound 4, a percentage reported as inhibition, at one concentration (the size of the read-out at that concentration, not a potency): < 10%
Compound 4 ended at the assay's limit (the forecaster's own chance of this, stated with the estimate: 20%); middle value at least 14 percentage points from the limit.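

Trifluoromethyl in place of hydrogen on an aromatic carbon, ortho to a large group, gives a number at least 19.6 percentage points lower from compound 1 to compound 4 (beyond the scatter) in this assay, so a large drop on this ring is not tied to the carboxy group alone. All three changes to this ring shown so far end beyond the scatter below compound 1, with none going against that, and the ortho place now joins the two carboxy places among those where a substituent gives such a drop. The value of compound 4 is a limit of this assay and not a number, so the full size of its step stays unknown, and one other compound shown sits at the same limit: the limit of < 10% in this assay, at which 2 of the 4 values shown sit.

Compound 3 and compound 4 cannot be put in order, and the effect of the group cannot be separated from that of its place, as trifluoromethyl appears at only one place and carboxy at two others. On these data alone, whether a single fluorine, a chlorine, a methyl or an amine at the same ortho place would keep the number of compound 1 remains open, as does trifluoromethyl elsewhere on the ring.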